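Swapping fluoro for methoxy on a cytotoxicity probe

A few compounds are considered here, and "the series" means these few. Any claim that something is new, unique, unknown or untested is made for them only; others in the source may bear on it.

In an ADME assay on Huh-7 cells (Homo sapiens) for cytotoxicity, read by XTT assay, with a stated time of 3 days, tested at 200 uM (a lower number here means a stronger effect, a higher number a weaker effect of the compound at the concentration tested), compound 1 `COc1ccc(-c2cc(-c3ccc4cc(F)ccc4n3)n(-c3ccccc3)n2)cc1` gives 98.9%, while compound 2 `NS(=O)(=O)c1ccc(-n2nc(-c3ccc(F)cc3)cc2-c2ccc3cc(F)ccc3n2)cc1` gives 43%, the lowest of the two numbers and well beyond the scatter from compound 1. Compound 3 `COc1ccc(-c2cc(-c3ccc4cc(F)ccc4n3)n(-c3ccc(S(N)(=O)=O)cc3)n2)cc1` has not been measured yet. It differs from compound 2 in one place: methoxy in place of fluoro on an aromatic carbon. Going by the values given here, no measured pair shows this change on its own, so a modest step upward from compound 2 to compound 3 is expected, a number 17 percentage points higher from compound 2 to compound 3 (beyond the scatter), without confidence in its direction. In this assay compound 3 is therefore expected to give about 60%, with a range from 35% to 95%.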

Compound 3, a percentage reported as activity, at one concentration (the size of the read-out at that concentration, not a potency): 89.5%
Beside the measured number, compound 3's estimate is 29.5 percentage points below it, and the stated range covers the measured number.
By their numbers in this assay, from the lowest: compound 2; then compounds 3 and 1 (each within the scatter of the next).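

In this assay, the change from 4-fluorophenyl to 4-methoxyphenyl has a large effect on its own (a number 46.5 percentage points higher from compound 2 to compound 3 (beyond the scatter)). With the methoxy group in place, sulfamoyl in place of hydrogen on an aromatic carbon gives a step that cannot be told from the scatter (a number 9.4 percentage points lower from compound 1 to compound 3 (within the scatter)). Nothing at hand explains either step. Going by these compounds, how an amine or a carboxylic acid at this place would read remains open. So does whether the fluoro-to-methoxy step would stay as large in a compound without the sulfamoyl group.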